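The source may hold more compounds than are shown below. What is called first, only, known or untested is meant among the compounds shown, and "the series" means these compounds.

On these data alone, the series gathers three measured members and one whose number is still unknown. Compound 1 `CNC(=O)C[S+]([O-])C(c1ccccc1)c1ccccc1` and compound 2 `CNC(=O)CSC(c1ccccc1)c1ccccc1` share the same diphenylmethyl core and a methylcarbamoyl group, differing only in the link between them. Compound 3 `O=C(CSC(c1ccc(Br)cc1)c1ccc(Br)cc1)NCCCc1ccccc1` carries bromine on both rings and a longer amide substituent. In an assay on brain (strain Sprague-Dawley) for displacement of a labelled ligand from sodium-dependent dopamine transporter (Rattus norvegicus), read by scintillation counting, with a stated time of 120 min (a lower number here means a stronger inhibitor, a higher number a weaker inhibitor), compound 1 gives 13100 nM, compound 2 gives 19300 nM and compound 3 gives 238 nM. Compound 2 stands at the highest number of the three; its gap to compound 1 lies within the scatter, so the two cannot be told apart, while the gap to compound 3 is wide and beyond the scatter.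

Compound 4 `CCCCNC(=O)CSC(c1ccccc1)c1ccccc1` is the next member, and it is reached from compound 2 by a single change: propyl in place of hydrogen on a saturated chain carbon bound to an amide-type nitrogen. Among the compounds with values here, no step between measured compounds isolates this change, so its effect must be judged from the whole set. Compound 3 shows that a larger substituent on the amide nitrogen can sit alongside a far lower number, but its bromines make a second difference, so the comparison is only suggestive.

Compound 4 is therefore expected to show a moderate drop in number, with a step of a 4.3-fold lower number from compound 2 to compound 4 (0.63 log units; beyond the scatter) from compound 2. Compound 4 is estimated at 4500 nM, within a range from 1500 nM to 13000 nM.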

Compound 4, inhibition constant: 23600 nM
Compound 4: the middle estimate sits 5.2-fold (0.72 log units) below what was measured; the measured number lies above the stated range.
By their numbers in this assay, from the lowest: compound 3; then compounds 1, 2 and 4 (each within the scatter of the next).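

Propyl in place of hydrogen on a saturated chain carbon bound to an amide-type nitrogen, which turns methylcarbamoyl into butylcarbamoyl, gives in this assay a 1.2-fold higher number from compound 2 to compound 4 (0.09 log units; within the scatter), so compound 2 and compound 4 cannot be told apart. Within the data shown here, this is the first reading of this position on its own, with the rest of the molecule unchanged, and it shows that going from methyl to butyl here leaves the number in the same range on the unbrominated core. The hint taken from compound 3 therefore finds no support in this plain alkyl chain, and nothing measured here offers an explanation for the flat result.

On these data alone, compound 3 differs from every other compound in more than one place, so the steps to it cannot be read, and it remains open whether its number goes with the bromines, with its phenyl-bearing amide substituent or with the two together. Also open, as far as these compounds go, is how this position responds to other groups, such as an amine or a carboxylic acid in place of the propyl, or a longer chain such as octyl.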